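The source may hold more compounds than are shown below. What is called first, only, known or untested is meant among the compounds shown, and "the series" means these compounds.

Compound 1, whose structure is `COc1cc(-c2nc3cc(/C=C4\SC(=O)NC4=O)ccc3[nH]2)cc(OC)c1OC`, was tested in a functional assay on PC-3 cells (Homo sapiens) for inhibition, read by MTT assay, with a stated time of 48 h (a lower number here means a stronger inhibitor, a higher number a weaker inhibitor), where compound 1 gives 12000 nM. Among the two numbers recorded so far this is the highest, but its nearest neighbour lies within the usual scatter: compound 2, with the structure `COc1cc(OC)c(-c2nc3cc(/C=C4\SC(=O)NC4=O)ccc3[nH]2)cc1OC`, gives in this assay a value of 6320 nM, and the gap between the two is too small to read as a difference in strength. Compound 2 differs from compound 1 in the arrangement of the three methoxy groups on the aryl ring, and nothing more can be said of that pair than what the two values show.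

Compound 3, whose structure is `COc1cc(-c2nc3cc(/C=C4\SC(=O)N(Cc5ccccc5)C4=O)ccc3[nH]2)cc(OC)c1OC`, is the next compound to be measured. It differs from compound 1 in one place: benzyl in place of hydrogen on an amide-type nitrogen in a ring. Within the data shown here, no pair of measured compounds carries this change, so there is no measured step to lean on. The step from compound 1 to compound 3 is expected to be small, and the estimate a 1.5-fold lower number from compound 1 to compound 3 (0.18 log units; within the scatter) leans slightly toward a lower number without confidence that it will clear the scatter. For compound 3 the estimated value is 8000 nM, with an expected range from 2000 nM to 40000 nM.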

Compound 3, half-maximal inhibitory concentration: 2500 nM
The estimate for compound 3 lay 3.2-fold (0.51 log units) above the measured number; the measured number falls inside the stated range.
By their numbers in this assay, from the lowest: compound 3; then compounds 2 and 1 (each within the scatter of the next).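

Among these compounds, putting benzyl in place of the hydrogen on the amide-type nitrogen in a ring gives in this assay a 4.8-fold lower number from compound 1 to compound 3 (0.68 log units; beyond the scatter) and so provides the first step in this set that lies beyond the scatter. The earlier pair changed only the arrangement of the methoxy groups on the aryl ring and left this nitrogen with its hydrogen, so it said nothing about this position, two ring bonds from the ring sulfur; compound 3 shows that the hydrogen there can be replaced by a much larger group without loss, and with a modest gain, in this cell assay. Nothing at hand accounts for that gain, which rests on this one pair.

The compounds shown leave open whether the benzyl ring itself matters or any group on this nitrogen would serve, as a plain methyl or a longer chain such as phenethyl might tell. They also leave open whether a benzyl carrying a carboxylic acid or an amine would keep the gain, and whether benzyl would give a similar step on the methoxy arrangement of compound 2.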